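The compounds below may be only part of what the source reports. "The series", "measured", "known", "first", "only" and "open" are said of these compounds alone.

Compound 2 `Clc1ccc(-c2cc(-c3ccc(Cl)cc3)[nH]n2)cc1` has the highest number of the three measured compounds: in an assay on mitochondria from brain for inhibition of Amine oxidase [flavin-containing] B (Bos taurus), read by fluorescence (a higher number here means a weaker inhibitor, a lower number a stronger inhibitor), compound 2 gives 6030 nM, whereas compound 1 `Clc1ccc(-c2cc(-c3ccccc3)n[nH]2)cc1` gives 6.03 nM and compound 3 `Fc1ccc(-c2cc(-c3ccc(Cl)cc3)n[nH]2)cc1` gives 40.7 nM. Compound 4 `Cc1ccc(-c2cc(-c3ccc(Cl)cc3)[nH]n2)cc1` differs from compound 2 by methyl in place of chloro on an aromatic carbon. Going by the values given here, two measured steps touch the same position: a 1000-fold higher number from compound 1 to compound 2 (3.00 log units; beyond the scatter), and a 150-fold lower number from compound 2 to compound 3 (2.17 log units; beyond the scatter). Both are large, and both show that a change at this position swings this assay widely, with chloro giving the weakest inhibition seen. Putting methyl in place of chloro is therefore expected to give a markedly lower number, though how far remains uncertain. Compound 4 is estimated at 300 nM, within 40 nM to 3000 nM, an expected step of a 20-fold lower number from compound 2 to compound 4 (1.30 log units; beyond the scatter).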

Compound 4, half-maximal inhibitory concentration: 8.91 nM
For compound 4 the middle estimate is 34-fold (1.53 log units) above the measured one; the whole stated range lies above it.
By their numbers in this assay, from the lowest: compounds 1 and 4 (each within the scatter of the next); then compound 3; then compound 2.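

Methyl in place of chloro gives a 680-fold lower number from compound 2 to compound 4 (2.83 log units; beyond the scatter) in this assay, so the high number of compound 2 goes with chloro itself, not with simply having a group at this position. Methyl in place of hydrogen gives only a 1.5-fold higher number from compound 1 to compound 4 (0.17 log units; within the scatter), so this position can carry methyl without a change beyond the scatter. No available evidence explains why chloro stands apart. Still open, as far as these compounds go, is how groups such as methoxy, an amine or a carboxylic acid would behave at this position.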